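A few compounds are considered here, and "the series" means these few. Any claim that something is new, unique, unknown or untested is made for them only; others in the source may bear on it.

Working notes on the series. Compound 1 `CCCNC(=O)c1ccc(Oc2nc(-c3c(C)noc3C)cnc2N)cc1`, compound 2 `Cc1noc(C)c1-c1cnc(N)c(Oc2ccc(C(=O)NC3CCCCC3)cc2)n1` and compound 3 `Cc1noc(C)c1-c1cnc(N)c(Oc2ccc(C(=O)Nc3ccccc3Cl)cc2)n1` share one core and differ only in the group on the amide-type nitrogen. In a functional assay on HepG2 cells (Homo sapiens) for inhibition, read by MTT assay, with a stated time of 72 h (on this read-out higher numbers stand for weaker inhibition and lower numbers for stronger inhibition), compound 1 gives 6880 nM. In this assay compound 2 gives 5420 nM. For compound 3 this assay reports only a limit, > 100000 nM, not a number. The step of a 1.3-fold lower number from compound 1 to compound 2 (0.10 log units; within the scatter) leaves the two alkyl amides level; the steps of an at least 14-fold higher number from compound 1 to compound 3 (1.16 log units; beyond the scatter) and an at least 18-fold higher number from compound 2 to compound 3 (1.26 log units; beyond the scatter) set compound 3 apart at the weak end of the three, sitting on the limit (the limit of > 100000 nM in this assay, at which 1 of the 3 values shown sits).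

Compound 4 `Cc1noc(C)c1-c1cnc(N)c(Oc2ccc(C(=O)Nc3ccc(Cl)cc3)cc2)n1` is the unmeasured member. It differs from compound 3 as 4-chlorophenyl in place of 2-chlorophenyl on an amide-type nitrogen. For the measured compounds named here, no measured step covers a change of this kind: both steps into compound 3 replace an alkyl group by 2-chlorophenyl, and compound 4 keeps an aryl group of the same atoms on that nitrogen, so the two large steps say only that aryl amides in this set sit far above the alkyl amides. The expectation in this assay is therefore a step of an at least 1.2-fold lower number from compound 3 to compound 4 (0.09 log units; that floor lies within the scatter), small or none beyond the scatter, with a fair chance that again only a limit is reported. Compound 4 is expected at 80000 nM, within a range from 15000 nM to 300000 nM.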

Compound 4, half-maximal inhibitory concentration: 14400 nM
Estimate against measurement, compound 4: 5.6-fold (0.74 log units) above, and the stated range ends above it.
By their numbers in this assay, from the lowest: compounds 2 and 1 (each within the scatter of the next); then compound 4. At a limit, above all of these: compound 3.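

The change of 2-chlorophenyl to 4-chlorophenyl on an amide-type nitrogen uses the same atoms joined differently, yet in this assay it gives an at least 6.9-fold lower number from compound 3 to compound 4 (0.84 log units; beyond the scatter), so the aryl amides do not form one uniformly weak group and the placing of the chlorine on the phenyl ring matters at this position. Against the alkyl amides, the 4-chlorophenyl amide stays on the weak side, with a 2.7-fold higher number from compound 2 to compound 4 (0.42 log units; beyond the scatter) and a 2.1-fold higher number from compound 1 to compound 4 (0.32 log units; beyond the scatter), and both of these modest steps are much smaller than the large steps from the same two compounds into compound 3. The step between the two chlorophenyl amides is only a floor, since compound 3 has a limit and not a number: the limit of > 100000 nM in this assay, at which 1 of the 4 values shown sits.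

As far as these compounds go, whether an unsubstituted phenyl or a benzyl group on this nitrogen would sit near compound 4 or near compound 3 stays open, as does how a longer alkyl chain would compare with the propyl and cyclohexyl amides. The compounds shown also give no cause for the gap between the two chlorophenyl amides, and its full size remains unknown.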